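Swapping an Amide for a Small Amine on the Benzyl Arm

A few compounds are considered here, and "the series" means these few. Any claim that something is new, unique, unknown or untested is made for them only; others in the source may bear on it.

Two compounds share one core and differ only in the group on a saturated chain carbon bound to an aromatic carbon. Compound 1 `Cn1nc2c(=O)n(CC3(O)CCN(Cc4ccc(-c5ccco5)cc4Cl)CC3)cnc2c1-c1ccc(CO)cc1` carries a hydroxy there, and in an assay on isolated protein for inhibition of ubiquitin carboxyl-terminal hydrolase 7 (Homo sapiens), with stated times of 30 min and 2 h (on this read-out higher numbers stand for weaker inhibition and lower numbers for stronger inhibition), compound 1 gives 42.5 nM. Compound 2 `Cn1nc2c(=O)n(CC3(O)CCN(Cc4ccc(-c5ccco5)cc4Cl)CC3)cnc2c1-c1ccc(CNC(=O)C(F)(F)F)cc1` carries a ((trifluoromethyl)carbonyl)amino group instead, and in this assay compound 2 gives 2060 nM. Among the measured compounds shown here, that exchange is the only measured step, a 48-fold higher number from compound 1 to compound 2 (1.69 log units; beyond the scatter), so compound 2 stands as the weaker of the two by a wide margin.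

Compound 3 `CN(C)Cc1ccc(-c2c3ncn(CC4(O)CCN(Cc5ccc(-c6ccco6)cc5Cl)CC4)c(=O)c3nn2C)cc1` is not yet measured. It differs from compound 2 by dimethylamino in place of ((trifluoromethyl)carbonyl)amino on a saturated chain carbon bound to an aromatic carbon. For the measured compounds named here, no measured pair shows this exact exchange; the only guide is that the ((trifluoromethyl)carbonyl)amino group of compound 2 was far weaker than the hydroxy of compound 1, and dimethylamino, like hydroxy, is a small group with one hydrogen-bond acceptor, though it lacks the hydrogen-bond donor. Compound 3 is therefore expected to recover much of the loss, a step of a 14-fold lower number from compound 2 to compound 3 (1.14 log units; beyond the scatter). The estimate for compound 3 in this assay is 150 nM, within a range from 30 nM to 800 nM.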

Compound 3, half-maximal inhibitory concentration: 131 nM
For compound 3 the middle estimate is 1.1-fold (0.06 log units) above the measured one; the range from low to high includes it.
By their numbers in this assay, from the lowest: compound 1; then compound 3; then compound 2.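

In this assay, the position on a saturated chain carbon bound to an aromatic carbon does not lose activity with every replacement of hydroxy: putting dimethylamino in place of ((trifluoromethyl)carbonyl)amino gives a 16-fold lower number from compound 2 to compound 3 (1.20 log units; beyond the scatter) and so recovers most of the loss seen with compound 2. Dimethylamino has no hydrogen-bond donor, so a donor on this group is not required for activity in the nanomolar range, yet the exchange is not neutral, as the comparison with hydroxy gives a 3.1-fold higher number from compound 1 to compound 3 (0.49 log units; beyond the scatter) and leaves hydroxy ahead by a modest margin. No measurement in hand explains why these three groups rank as they do.

On these data alone, it remains open whether the large loss with compound 2 belongs to the trifluoromethyl or to the amide itself, a question that a plain acetylamino group at this position could help to separate. Also open, as far as these compounds go, is whether an amine that keeps a hydrogen on nitrogen, such as methylamino, or a ring amine such as morpholine, would close the remaining gap to hydroxy.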